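This account rests on a few compounds, and the source may have more. Where it says the series, first, only, none or still open, it means among the compounds named here.

Measured compounds:
- compound 1 `Nc1nc(N)nc(-c2ccccc2Br)n1`: 1.26
- compound 2 `COc1ccc(Br)cc1-c1nc(N)nc(N)n1`: 1.53
- compound 3 `CCCNc1c(C)n(C)c(=O)n(-c2ccccc2)c1=O`: 1.2

In a physicochemical assay for lipophilicity (on this read-out lower numbers stand for lower lipophilicity and higher numbers for higher lipophilicity), compound 3 gives 1.2, the low end of the three numbers. Compound 1 gives 1.26, a value that lies within the usual scatter of compound 3, so the two cannot be told apart. Compound 2 gives 1.53, which stands beyond the scatter above compound 3. Among the compounds with values here, compounds 1 and 2 share a core that compound 3 does not, and no single-point step between measured compounds is available.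

Compound 4 `Cc1c(N2CCCC2)c(=O)n(-c2ccccc2)c(=O)n1C` has not yet been measured in this assay. It differs from compound 3 in one place: pyrrolidin-1-yl in place of propylamino on an aromatic carbon. The exchange removes one hydrogen-bond donor and adds one heavy atom within a five-membered non-aromatic ring.

Within the data shown here, with no measured step of this kind to lean on, the expectation for compound 4 rests on the change alone. Compound 4 is expected to give 1.6, with a range from 1.2 to 2. This estimate means an expected step of a number 0.40 log units higher from compound 3 to compound 4 (beyond the scatter), a modest rise, likely just beyond the scatter rather than a large move.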

Compound 4, partition coefficient: 2.26
Estimate against measurement, compound 4: 0.66 log units below; the whole stated range lies below it.
By their numbers in this assay, from the lowest: compounds 3, 1 and 2 (each within the scatter of the next, the first and the last beyond it); then compound 4.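

In this assay, within the data shown here, pyrrolidin-1-yl in place of propylamino on this aromatic carbon gives a number 1.06 log units higher from compound 3 to compound 4 (beyond the scatter), the first step between measured compounds that differ in one place. Among these compounds, it shows that this position, ortho to a methyl group and meta to a phenyl group, can carry a large change in this read-out, which the earlier compounds could not show. The exchange removes a hydrogen-bond donor and adds a five-membered non-aromatic ring in the same move, and no measurement here offers a cause for the step.

The compounds shown leave open whether the loss of the donor or the presence of the ring accounts for the step. Diethylamino or piperidine on the same aromatic carbon would bear on that question, and the step's size on another core also remains unknown.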